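A Methoxyphenyl Variant Weighed Against Two Measured Analogues

The source may hold more compounds than are shown below. What is called first, only, known or untested is meant among the compounds shown, and "the series" means these compounds.

Compound 2 `O=C(O)C[C@H](O)C[C@H](O)CCn1c(-c2ccc(F)cc2)nc(C(=O)NCc2cccc(F)c2)c1C1CC1` stands lowest of the two numbers measured in a functional assay on L6 cells (Rattus norvegicus) for inhibition, read by scintillation counting, with a stated time of 3 h (a higher number here means a weaker inhibitor, a lower number a stronger inhibitor), where compound 2 gives 444 nM. Among the compounds with values here, its only neighbour, compound 1 `Cc1ccccc1CNC(=O)c1nc(-c2ccc(F)cc2)n(CC[C@@H](O)C[C@@H](O)CC(=O)O)c1C1CC1`, gives 4850 nM in this assay, and the sole measured step, an 11-fold lower number from compound 1 to compound 2 (1.04 log units; beyond the scatter), shows that the group on the saturated chain carbon bound to the amide-type nitrogen can shift the result considerably. Compound 3 `COc1ccc(CNC(=O)c2nc(-c3ccc(F)cc3)n(CC[C@@H](O)C[C@@H](O)CC(=O)O)c2C2CC2)cc1` differs from compound 2 by 4-methoxyphenyl in place of 3-fluorophenyl on a saturated chain carbon bound to an amide-type nitrogen. That earlier large step bears directly on this change, since it alters the same group at the same place, yet it cannot say whether 4-methoxyphenyl will fare like 3-fluorophenyl or like 2-methylphenyl. A moderate step toward a weaker inhibitor, a 2.5-fold higher number from compound 2 to compound 3 (0.39 log units; beyond the scatter), is therefore expected, with wide uncertainty. Compound 3 is estimated at 1100 nM in this assay, within a range from 250 nM to 4500 nM.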

Compound 3, half-maximal inhibitory concentration: 6400 nM
Beside the measured number, compound 3's estimate is 5.8-fold (0.76 log units) below it, and the stated range ends below it.
By their numbers in this assay, from the lowest: compound 2; then compounds 1 and 3 (each within the scatter of the next).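

In this assay the 4-methoxyphenyl group falls with 2-methylphenyl and not with 3-fluorophenyl: the change from 3-fluorophenyl is large (a 14-fold higher number from compound 2 to compound 3 (1.16 log units; beyond the scatter)), while the change from 2-methylphenyl stays within the scatter (a 1.3-fold higher number from compound 1 to compound 3 (0.12 log units; within the scatter)). Among the three groups on this saturated chain carbon bound to an amide-type nitrogen, 3-fluorophenyl alone therefore stands apart from the other two, which cannot be told apart from each other. Nothing available explains why these groups divide in this way.

Within the data shown here, whether 3-fluorophenyl is the only group at this place to reach so low a number remains open. So does how an amine or a longer chain in its stead would read in this assay.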